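Extending the Alkoxy Chain on a Thiourea Series

This account rests on a few compounds, and the source may have more. Where it says the series, first, only, none or still open, it means among the compounds named here.

Compound 1 `COc1cc(C(C)(C)C)ccc1C/N=C(\S)NCc1ccc(NS(C)(=O)=O)cc1` gives 2400 nM in a functional assay for inhibition of Vanilloid receptor (Rattus norvegicus); a lower number here means a stronger inhibitor, a higher number a weaker inhibitor.
Compound 2 `CCCCCOc1cc(C(C)(C)C)ccc1C/N=C(\S)NCc1ccc(NS(C)(=O)=O)cc1` gives 70 nM in this assay.

For the measured compounds named here, of the two compounds measured, compound 2 carries the lower number; its only neighbour is compound 1, separated from it by a 34-fold lower number from compound 1 to compound 2 (1.54 log units; beyond the scatter). Compound 3 `CCCCCCOc1cc(C(C)(C)C)ccc1C/N=C(\S)NCc1ccc(NS(C)(=O)=O)cc1` differs from compound 2 by methyl in place of hydrogen on a saturated chain carbon, five bonds along the chain from an oxygen on an aromatic ring. Going by the values given here, only one measured step bears on this change, a 34-fold lower number from compound 1 to compound 2 (1.54 log units; beyond the scatter), which covers the growth of the same chain from its shortest to its present length and was large. Among the compounds with values here, no measured pair shows whether one further unit carries that trend onward, and such a gain cannot simply be assumed to repeat. The step in this assay from compound 2 to compound 3 is therefore expected to be modest, either a somewhat lower number or none beyond the scatter. Compound 3 is estimated to give 50 nM in this assay, within a range from 20 nM to 150 nM, which corresponds to an expected step of a 1.4-fold lower number from compound 2 to compound 3 (0.15 log units; within the scatter).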

Compound 3, half-maximal inhibitory concentration: 150 nM
The estimate for compound 3 lay 3.0-fold (0.48 log units) below the measured number, within the range that was stated.
By their numbers in this assay, from the lowest: compound 2; then compound 3; then compound 1.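

In this assay, the chain on the oxygen does not keep improving with length: one further methyl at its end turns the trend around, giving a 2.1-fold higher number from compound 2 to compound 3 (0.33 log units; beyond the scatter), a modest step but one beyond the scatter. The longer chain nevertheless keeps most of what chain growth had gained, with a 16-fold lower number from compound 1 to compound 3 (1.20 log units; beyond the scatter), so this position still tolerates the added carbon far better than the shortest chain would suggest, and among these three compounds, compound 2 has the lowest number, with its steps to both others beyond the scatter. No measurement shown here accounts for this turn in the trend.

The compounds shown leave open how the number changes along the shorter chains between compound 1 and compound 2, and whether a still longer chain would continue the rise seen at compound 3 or level off. They also leave open whether a branched chain of similar length, or a chain ending in an amine or a carboxylic acid, would be received at this position as the plain chains are.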